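A few compounds are considered here, and "the series" means these few. Any claim that something is new, unique, unknown or untested is made for them only; others in the source may bear on it.

Going by the values given here, compound 1 (`CCCCc1cc2c(=O)c(CC)c(C)[nH]c2cc1OCCOc1ccccc1`) holds the only actual number so far: in an ADME assay on J774 cells (Mus musculus) for antiproliferative activity, with a stated time of 72 h (on this read-out lower numbers stand for an effect already at smaller amounts and higher numbers for an effect only at larger amounts of compound), compound 1 gives 1000 nM. With methyl where compound 1 carries butyl, compound 2 (`CCc1c(C)[nH]c2cc(OCCOc3ccccc3)c(C)cc2c1=O`) reads > 30000 nM, which is a limit of the assay. Compound 3 (`CCc1c(C)[nH]c2cc(OCCOc3ccccc3)c(Br)cc2c1=O`), with bromo at that place, reads > 25000 nM, also a limit. Both measured departures from butyl are large: an at least 30-fold higher number from compound 1 to compound 2 (1.47 log units; beyond the scatter), and an at least 25-fold higher number from compound 1 to compound 3 (1.39 log units; beyond the scatter). Between the two limits, the record shows a step that the two limits leave unreadable from compound 2 to compound 3.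

Compound 4 (`CCCCc1cc2c(=O)c(-c3ccc(C(F)(F)F)cc3F)c(C)[nH]c2cc1OCCOc1ccccc1`) keeps the butyl group and changes another place: 2-fluoro-4-(trifluoromethyl)phenyl in place of ethyl on an aromatic carbon. In words, 2-fluoro-4-(trifluoromethyl)phenyl replaces ethyl on an aromatic carbon. Among the compounds with values here, no measured step touches this place, so the steps bear on it only indirectly, and the large ones do not transfer to it. With butyl retained, the reference remains compound 1 at 1000 nM. A moderate move toward a higher number in this assay is expected, with wide uncertainty. The expected step is a 3.0-fold higher number from compound 1 to compound 4 (0.48 log units; beyond the scatter). The estimate for compound 4 is 3000 nM, with an expected range from 600 nM to 20000 nM.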

Compound 4, half-maximal effective concentration: 19000 nM
The estimate for compound 4 lay 6.3-fold (0.80 log units) below the measured number, and the stated range covers the measured number.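

Going by these compounds alone, with butyl kept, this is the first measured change at the aromatic carbon two atoms from the ring nitrogen, and in this assay it is a large one: a 19-fold higher number from compound 1 to compound 4 (1.28 log units; beyond the scatter). The place of ethyl therefore joins the place of butyl as one where a single change moves the number well beyond the scatter, and here the replacement swaps a group of 2 heavy atoms and no ring for one of 11 heavy atoms with a six-membered aromatic ring, while compound 4 still gives a number, 19000 nM, and not a limit. Nothing in the data shown bears on why this exchange carries such a cost.

Within the data shown here, open is whether the step follows from the added aromatic ring itself or from the fluoro and trifluoromethyl groups it carries, since only this one replacement of ethyl stands so far. A plain phenyl at this place would address that question, and a propyl chain would show how the number responds to a modest lengthening of ethyl without any ring.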